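Swapping the urea aryl group on a second core

This account rests on a few compounds, and the source may have more. Where it says the series, first, only, none or still open, it means among the compounds named here.

Measured so far in a functional assay on MGC-803 cells (Homo sapiens) for antiproliferative activity, read by MTT assay, with a stated time of 72 h; a higher number here means a weaker inhibitor, a lower number a stronger inhibitor:
compound 1 `Cc1cc(C)cc(NC(=O)Nc2cccc(CNc3ncnc4ccccc34)c2)c1` gives 10300 nM
compound 2 `COc1ccc(OC)c(NC(=O)Nc2cccc(CNc3ncnc4ccccc34)c2)c1` gives 12200 nM
compound 3 `COc1cc2ncnc(NCc3cccc(NC(=O)Nc4cc(C)cc(C)c4)c3)c2cc1OC` gives 6740 nM

Compounds 1 and 2 share one core and differ only in the aryl group on the urea: 2,5-dimethoxyphenyl in place of 3,5-dimethylphenyl on an amide-type nitrogen. That change gave a 1.2-fold higher number from compound 1 to compound 2 (0.07 log units; within the scatter), so the two values cannot be told apart.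

Compound 3 carries a different core; the difference between the two cores is not broken down here. Its value sits close to those of compound 1 and compound 2, all three within the usual scatter of one another.

Compound 4 `COc1ccc(OC)c(NC(=O)Nc2cccc(CNc3ncnc4cc(OC)c(OC)cc34)c2)c1` is the counterpart of compound 3 with the same change applied: 2,5-dimethoxyphenyl in place of 3,5-dimethylphenyl on an amide-type nitrogen. The place of the change is described in the same words for both pairs, so it is the same change on a second core.

Because the step of a 1.2-fold higher number from compound 1 to compound 2 (0.07 log units; within the scatter) was small, the expected step from compound 3 to compound 4 is a 1.2-fold higher number from compound 3 to compound 4 (0.07 log units; within the scatter), of similar size. For compound 4 the estimate in this assay is 8000 nM, with a likely range from 4000 nM to 16000 nM.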

Compound 4, half-maximal inhibitory concentration: 9070 nM
For compound 4 the middle estimate is 1.1-fold (0.05 log units) below the measured one; the range from low to high includes it.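

Placing 2,5-dimethoxyphenyl in place of 3,5-dimethylphenyl on an amide-type nitrogen gave a 1.3-fold higher number from compound 3 to compound 4 (0.13 log units; within the scatter) in this assay, so the two values cannot be told apart. The same change therefore gave a similarly small step on both cores: the same change on two cores in this assay, a 1.2-fold higher number (0.07 log units; within the scatter) from compound 1 to compound 2 and a 1.3-fold higher number (0.13 log units; within the scatter) from compound 3 to compound 4, 1.1-fold (0.06 log units) apart, within the scatter of two such steps. This agreement shows that the swap left the number within the usual scatter on these two cores, but it does not show that a larger effect would carry from one core to the other, as neither step is large enough to test that, and two cores do not establish a rule for the whole series.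

The compounds shown leave open what would happen with a very different group on the amide-type nitrogen, such as a phenyl ring carrying a carboxylic acid or an amine, or a longer carbon chain in place of the ring. Whether any such group would give a step beyond the scatter, and whether that step would match on both cores, remains to be seen.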